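The compounds below may be only part of what the source reports. "The series", "measured", "known", "first", "only" and "open" are said of these compounds alone.

Compound 1, `O=C1COc2ccc(-c3cccc(NS(=O)(=O)c4ccc(F)cc4)c3)cc2N1c1ccccc1`: > 40000 nM
Compound 2, `O=C1COc2ccc(-c3ccc(O)cc3)cc2N1`: > 40000 nM

In a functional assay on MCF7 cells (Homo sapiens) for antiproliferative activity, read by MTT assay, with a stated time of 72 h (on this read-out higher numbers stand for weaker inhibition and lower numbers for stronger inhibition), compound 1 gives > 40000 nM, a limit of the assay rather than a number. Compound 2 gives > 40000 nM, also a limit. Both results sit at the limit of > 40000 nM in this assay, at which 2 of the 2 values shown sit, so compound 1 stands at the edge of what the measurement can show. Compound 3, `COc1ccc(N2C(=O)COc3ccc(-c4cccc(NS(=O)(=O)c5ccc(F)cc5)c4)cc32)cc1`, differs from compound 1 by methoxy in place of hydrogen on an aromatic carbon. Going by the values given here, no measured pair connects these two, so no direction can be read; a step that the limit leaves unreadable from compound 1 to compound 3 is expected, none beyond the scatter. Compound 3 is estimated at 50000 nM, between 15000 nM and 200000 nM.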

Compound 3, half-maximal inhibitory concentration: 32400 nM
For compound 3 the middle estimate is 1.5-fold (0.19 log units) above the measured one, within the range that was stated.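

In this assay, the change from phenyl to 4-methoxyphenyl gives an at least 1.2-fold lower number from compound 1 to compound 3 (0.09 log units; that floor lies within the scatter). With 32400 nM, compound 3 is the first of the compounds shown to give a number rather than a limit, so this position, para to a large group, takes methoxy and still yields a readable result. For compound 1, > 40000 nM is a limit, so the step has only a floor: the limit of > 40000 nM in this assay, at which 2 of the 3 values shown sit.

What the compounds shown leave open is whether an amine or a chlorine atom on the same aromatic carbon would move the read-out beyond the scatter. They also leave open how large the true step to methoxy is.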